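The source may hold more compounds than are shown below. What is called first, only, known or untested is meant among the compounds shown, and "the series" means these compounds.

The study offers three measured compounds and one untested. Compound 1 `O=C(CSc1nc(Nc2ccccc2)c2ccccc2n1)Nc1cccc(F)c1` gives 12700 nM in a functional assay on MGC-803 cells (Homo sapiens) for inhibition, read by MTT assay, with a stated time of 72 h; a lower number here means a stronger inhibitor, a higher number a weaker inhibitor. Going by the values given here, compound 2 `O=C(CSc1nc(Nc2ccccc2)c2ccccc2n1)Nc1cccc(Br)c1` gives 9620 nM in this assay, and the single change between them, bromo in place of fluoro on an aromatic carbon, amounts to a 1.3-fold lower number from compound 1 to compound 2 (0.12 log units; within the scatter). Compound 3 `C=CC(=O)Nc1cccc(NC(=O)CSc2nc(Nc3cccc(F)c3)c3ccccc3n2)c1` gives 6250 nM in this assay; this is the lowest of the three numbers, but its gap to compound 2 lies within the scatter and only its gap to compound 1 lies beyond it. Compound 4 `C=CC(=O)Nc1cccc(NC(=O)CSc2nc(Nc3ccc(Br)cc3)c3ccccc3n2)c1` differs from compound 3 in one place: 4-bromophenyl in place of 3-fluorophenyl on a nitrogen on an aromatic ring. Among the compounds with values here, the only measured step that bears on this exchange of halogens is a 1.3-fold lower number from compound 1 to compound 2 (0.12 log units; within the scatter), made at a different place in the molecule and within the scatter. Within the data shown here, the move of the halogen to another spot on that ring is covered by no measured pair. No step beyond the scatter is therefore expected in this assay. Compound 4 is estimated at 5500 nM, with a range from 2500 nM to 12000 nM. The expected step is a 1.1-fold lower number from compound 3 to compound 4 (0.06 log units; within the scatter).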

Compound 4, half-maximal inhibitory concentration: 11500 nM
Estimate against measurement, compound 4: 2.1-fold (0.32 log units) below; the range from low to high includes it.
By their numbers in this assay, from the lowest: compounds 3, 2, 4 and 1 (each within the scatter of the next, the first and the last beyond it).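

In this assay, the first change measured on the nitrogen-bound aromatic ring, 4-bromophenyl in place of 3-fluorophenyl, gives a 1.8-fold higher number from compound 3 to compound 4 (0.26 log units; within the scatter) and so stays within the scatter. This position therefore accepts a change of both halogen and ring position without a step that can be told from repeat measurement, at least for this one pair, whereas compound 1 and compound 2 spoke only to a halogen exchange at a different place in the molecule. No measurement shown here offers an explanation for the size of this step.

On these data alone, because the halogen and its ring position changed together, their separate contributions remain unknown. Also open, as far as these compounds go, is how this assay would respond to an amine or a carboxylic acid on this ring, or to a longer chain in place of the ring.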